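This account rests on a few compounds, and the source may have more. Where it says the series, first, only, none or still open, it means among the compounds named here.

Measured so far in a functional assay on MCF7 cells (Homo sapiens) for inhibition, read by sulforhodamine B assay, with a stated time of 48 h; on this read-out lower numbers stand for stronger inhibition and higher numbers for weaker inhibition: compound 1 `CSc1nn(-c2ccccc2)c2ncnc(N/N=C/c3ccccc3O)c12` gives 10.7 nM; compound 2 `COc1ccc(-n2nc(SC)c3c(N/N=C/c4ccc(Cl)cc4)ncnc32)cc1` gives 31.1 nM; compound 3 `COc1ccc(-n2nc(SC)c3c(N/N=C/c4ccc(F)cc4)ncnc32)cc1` gives 12.1 nM.

Compound 3 stands second highest of the three numbers, with compound 1 nearest within the scatter and compound 2 furthest beyond it.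

Compound 4 `COc1ccc(-n2nc(SC)c3c(N/N=C/c4ccccc4O)ncnc32)cc1` differs from compound 3 by 2-hydroxyphenyl in place of 4-fluorophenyl on a carbon with a double bond to nitrogen. Among the compounds with values here, the only measured step, a 2.6-fold lower number from compound 2 to compound 3 (0.41 log units; beyond the scatter), concerns a halogen exchange and does not bear directly on this change. Compound 1 carries the same 2-hydroxyphenyl arm on a core that differs elsewhere, and its value sits beside that of compound 3. No step beyond the scatter is therefore expected for a 1.1-fold lower number from compound 3 to compound 4 (0.04 log units; within the scatter). Compound 4 is estimated at 11 nM, within 5 nM to 25 nM.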

Compound 4, half-maximal inhibitory concentration: 13.3 nM
Beside the measured number, compound 4's estimate is 1.2-fold (0.08 log units) below it; measured number inside the range.
By their numbers in this assay, from the lowest: compounds 1, 3 and 4 (each within the scatter of the next); then compound 2.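

At the carbon with a double bond to nitrogen, 2-hydroxyphenyl and 4-fluorophenyl cannot be told apart in this assay, with a 1.1-fold higher number from compound 3 to compound 4 (0.04 log units; within the scatter), although the entering group brings a hydrogen-bond donor and acceptor. Against 4-chlorophenyl, the same change gives a 2.3-fold lower number from compound 2 to compound 4 (0.37 log units; beyond the scatter), so of these three arms on the shared core only 4-chlorophenyl stands apart. Methoxy in place of hydrogen on an aromatic carbon also leaves the 2-hydroxyphenyl arm's number within the scatter, with a 1.2-fold higher number from compound 1 to compound 4 (0.09 log units; within the scatter). No evidence on hand explains these numbers. As far as these compounds go, how an aminophenyl or carboxyphenyl arm at this carbon would read remains open.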